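From 4-hydroxypiperidin-1-yl to 3-hydroxypiperidin-1-yl

The source may report more compounds than this note shows. Statements on the series, on what has been measured and on what is new or still open speak of the compounds shown alone.

- compound 1 `O=C(NCc1ccc(S(=O)(=O)C2CCOCC2)cc1)N1Cc2ccncc2C1`: 6 mL/min/kg
- compound 2 `O=C(NCc1ccc(S(=O)(=O)N2CCC(O)CC2)cc1)N1Cc2ccncc2C1`: 6 mL/min/kg

Both values come from an ADME assay on microsomes from liver (Homo sapiens) for pharmacokinetics, read by LC-MS, with a stated time of 60 min, tested at 1 uM; on this read-out lower numbers stand for slow clearance and higher numbers for fast clearance. Among the compounds with values here, in this test compound 2 gives 6 mL/min/kg, level with its only measured neighbour, compound 1, at 6 mL/min/kg.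

The next structure, compound 3 `O=C(NCc1ccc(S(=O)(=O)N2CCC[C@H](O)C2)cc1)N1Cc2ccncc2C1`, keeps the shared core and has the same atoms as compound 2, joined differently. Only the group on the sulfonyl sulfur changes: 3-hydroxypiperidin-1-yl in place of 4-hydroxypiperidin-1-yl on a sulfonyl sulfur.

Within the data shown here, one measured step bears on this change: no change at the digits printed from compound 1 to compound 2 (within the scatter). It put 4-hydroxypiperidin-1-yl in place of oxan-4-yl on the sulfonyl sulfur, and it stayed within the scatter. Among the measured compounds shown here, this is thin evidence, since no measured compound yet carries 3-hydroxypiperidin-1-yl. With that single step as a guide, and starting from compound 2 at 6 mL/min/kg, no step beyond the scatter is expected in this assay, in either direction. The estimated change is a 1.2-fold higher number from compound 2 to compound 3 (0.07 log units; within the scatter). For compound 3 the expected value is 7 mL/min/kg, with an estimated range from 4 mL/min/kg to 13 mL/min/kg.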

Compound 3, clearance in the Homo sapiens assay: 8 mL/min/kg
Estimate against measurement, compound 3: 1.1-fold (0.06 log units) below; low and high end bracket the measured number.
By their numbers in the Homo sapiens assay, from the lowest: compounds 1, 2 and 3 (each within the scatter of the next).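

On the sulfonyl sulfur, the Homo sapiens assay gives a 1.3-fold higher number from compound 2 to compound 3 (0.12 log units; within the scatter) for 3-hydroxypiperidin-1-yl in place of 4-hydroxypiperidin-1-yl, and a 1.3-fold higher number from compound 1 to compound 3 (0.12 log units; within the scatter) for 3-hydroxypiperidin-1-yl in place of oxan-4-yl, so this position has now taken three different six-membered rings without a step beyond the scatter in this test, with compound 1 at 6 mL/min/kg, compound 2 at 6 mL/min/kg and compound 3 at 8 mL/min/kg. The same exchange of 4-hydroxypiperidin-1-yl for 3-hydroxypiperidin-1-yl also stays within the scatter in a physicochemical assay for solubility, in phosphate buffer, with a stated time of 24 h, at pH 7.4, tested at 100 uM (a higher number here means a more soluble compound, a lower number a less soluble compound), with a 1.2-fold higher number from compound 2 to compound 3 (0.09 log units; within the scatter), compound 2 at 174000 nM and compound 3 at 215000 nM, so the two compounds with the same atoms joined differently are not told apart by either read-out. Nothing available here explains these results.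

The compounds shown leave open whether the mirror-image form of 3-hydroxypiperidin-1-yl, which would carry the opposite arrangement at its defined stereocentre, would read the same in these two tests. They also leave open whether the same holds for groups that differ more from these rings on the sulfonyl sulfur, such as a plain piperidin-1-yl ring without the hydroxyl, a ring bearing an amine, or one bearing a carboxylic acid.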